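The source may report more compounds than this note shows. Statements on the series, on what has been measured and on what is new or still open speak of the compounds shown alone.

Measured compounds:
- compound 1 `Cc1ccc(NC(=O)COc2ccc3cc(/C=C4/SC(=O)NC4=O)ccc3c2)cc1Cl`, 1100 nM
- compound 2 `O=C(COc1ccc2cc(/C=C3/SC(=O)NC3=O)ccc2c1)Nc1c(F)cc(F)cc1Br`, 1100 nM
- compound 3 `CCOc1ccc2nc(NC(=O)COc3ccc4cc(/C=C5/SC(=O)NC5=O)ccc4c3)sc2c1`, 3600 nM

All three share one core and differ only in the aryl group on the amide-type nitrogen. In an assay on isolated protein for inhibition of histone deacetylase 4 (Homo sapiens), with a stated time of 1 h (on this read-out lower numbers stand for stronger inhibition and higher numbers for weaker inhibition), compound 2 stands level with compound 1: the step of no change at the digits printed from compound 1 to compound 2 (within the scatter) lies within the scatter, and the two together give the lowest numbers of the three. Compound 3 gives a higher number than compound 2, and that gap lies beyond the scatter.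

Compound 4 `O=C(COc1ccc2cc(/C=C3/SC(=O)NC3=O)ccc2c1)Nc1ccc(Br)c(Br)c1` is the next member: 3,4-dibromophenyl in place of 2-bromo-4,6-difluorophenyl on an amide-type nitrogen. Among the compounds with values here, the only measured step that bears on this kind of change is the one from compound 1 to compound 2, an exchange of one halogenated phenyl for another on the same amide-type nitrogen, which gave no change at the digits printed from compound 1 to compound 2 (within the scatter). Nothing here ties a particular halogen pattern on that phenyl to a shift in the number, so no step beyond the scatter is expected in this assay for the move to a third halogenated phenyl.

Compound 4 is therefore estimated at 1100 nM, with a range from 500 nM to 2500 nM. The expected step of no change at the digits printed from compound 2 to compound 4 (within the scatter) is thus no more than the scatter.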

Compound 4, half-maximal inhibitory concentration: 4900 nM
Compound 4: the middle estimate sits 4.5-fold (0.65 log units) below what was measured; measured number outside the range, above it.
By their numbers in this assay, from the lowest: compounds 1 and 2 (each within the scatter of the next); then compounds 3 and 4 (each within the scatter of the next).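

In this assay, the aryl group on the amide-type nitrogen is not indifferent among halogenated phenyls: a 4.5-fold higher number from compound 2 to compound 4 (0.65 log units; beyond the scatter) and a 4.5-fold higher number from compound 1 to compound 4 (0.65 log units; beyond the scatter) both lie beyond the scatter, whereas the earlier exchange, no change at the digits printed from compound 1 to compound 2 (within the scatter), stayed within it. Halogen on that phenyl therefore does not by itself hold the number at the level of compounds 1 and 2, since compound 4, with its 3,4-dibromophenyl, gives 4900 nM, within the scatter of compound 3 at 3600 nM. The data shown offer no measurement that accounts for this step.

Still open, as far as these compounds go, is whether the step belongs to the 3,4-dibromophenyl pattern as a whole or to one of its two bromines, which a phenyl carrying a single bromine would help to separate. Also open, from the compounds shown here alone, is how far the number moves on this phenyl with a group that is not a halogen, such as an amine or a carboxylic acid, or with no substituent at all.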